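Replacing Bromine with a Pyridyl Ring on a Shared Core

The source may hold more compounds than are shown below. What is called first, only, known or untested is meant among the compounds shown, and "the series" means these compounds.

Measured compounds:
Compound 1, `O=C1NCCN(c2cccc(Cl)n2)N1`: 4800 nM
Compound 2, `O=C1NCCN(c2cccc(Br)n2)N1`: 4600 nM
Compound 3, `CC1CN(c2cccc(Br)n2)NC(=O)N1`: 3100 nM

All three were tested in a functional assay on cells for inhibition of Polyunsaturated fatty acid 5-lipoxygenase (Homo sapiens); on this read-out lower numbers stand for stronger inhibition and higher numbers for weaker inhibition. Compound 2 stands second highest of the three numbers; its nearest is compound 1 and its furthest is compound 3, and both of those gaps lie within the usual scatter. Compound 4, `O=C1NCCN(c2cccc(-c3ccccn3)n2)N1`, has not yet been measured. It differs from compound 2 in a single place: pyridin-2-yl in place of bromo on an aromatic carbon.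

Two measured steps exist on this core. The step of a 1.0-fold lower number from compound 1 to compound 2 (0.02 log units; within the scatter) swaps one halogen for another, and the step of a 1.5-fold lower number from compound 2 to compound 3 (0.17 log units; within the scatter) adds a methyl on the saturated ring; each stayed within the scatter. Among the measured compounds shown here, neither step replaces the bromo with an aromatic ring, so no measured step bears directly on the change to compound 4. Both measured changes left the number essentially unmoved, and on that basis a step of modest size is expected in this assay, in either direction, with a wide range allowed for the larger structural change. The expected step is a 1.2-fold lower number from compound 2 to compound 4 (0.06 log units; within the scatter). Compound 4 is therefore estimated at 4000 nM, within a range from 1000 nM to 15000 nM.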

Compound 4, half-maximal inhibitory concentration: > 50000 nM
Compound 4: only a limit was reported (the forecaster's own chance of this, stated with the estimate: 15%); at least 12-fold (1.09 log units) between middle value and limit.
By their numbers in this assay, from the lowest: compounds 3, 2 and 1 (each within the scatter of the next). At a limit, above all of these: compound 4.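

Up to here, the aromatic carbon next to the ring nitrogen had only held halogens, and exchanging them left the number in this assay within the scatter, so this position had seemed undemanding. With pyridin-2-yl in place of bromo, six heavy atoms and a ring enter where one atom left, and the read-out shows a clear penalty: an at least 10-fold higher number from compound 2 to compound 4 (1.03 log units; beyond the scatter). The same holds against the chloro compound, an at least 10-fold higher number from compound 1 to compound 4 (1.01 log units; beyond the scatter), and since compound 4 is reported only as a limit of the assay, these steps give a minimum and not an exact size: the limit of > 50000 nM in this assay, at which 1 of the 4 values shown sits.

From the compounds shown here alone, what remains open is whether the weakening belongs to the aromatic ring as such, to its ring nitrogen, or simply to the larger size of the group, and a phenyl at this position would begin to separate these. Going by these compounds, whether smaller groups such as a methyl or an amine would hold the number near that of the halogens also stays open, so the tolerance of this position is known only from the two halogens and pyridin-2-yl.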